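The source may hold more compounds than are shown below. What is called first, only, known or untested is meant among the compounds shown, and "the series" means these compounds.

Working notes on the series

Three compounds have been run in a physicochemical assay for metabolic stability, read by HPLC, in phosphate buffer, at pH 7.4, tested at 10 uM (on this read-out higher numbers stand for a longer-lived compound and lower numbers for a shorter-lived compound), so far. Compound 1 `O=C(NCCCCc1ccccc1)n1cnc2ccccc21` gives 0.833 h in this assay. Compound 2 `Cc1cccc(CNC(=O)n2c(N)nc3ccccc32)c1` gives 0.183 h. Compound 3 `Cc1nc2ccccc2n1C(=O)NCCCCc1ccccc1` gives 0.117 h. The difference between the core of compound 2 and the core of compound 3 is not broken down here.

One single-point change has already been measured within the set: hydrogen in place of methyl on an aromatic carbon. This change made a 7.1-fold higher number from compound 3 to compound 1 (0.85 log units; beyond the scatter), so removal of that methyl goes with a longer-lived compound in this pair, the step lying beyond the usual scatter.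

Compound 4 `Nc1nc2ccccc2n1C(=O)NCc1ccccc1` has not yet been measured. It differs from compound 2 as follows: hydrogen in place of methyl on an aromatic carbon. Among the measured compounds shown here, this is the same kind of change as the one from compound 3 to compound 1, but not the same change: there the methyl left an aromatic carbon of a five-membered aromatic ring with 2 nitrogen, part of a fused system of two rings, between two ring nitrogen atoms and next to the ring atom that bears a large group, whereas here it leaves an aromatic carbon of a six-membered aromatic ring of carbon only, meta to a large group. For the measured compounds named here, with only one measured pair, and that pair at a different place in the molecule, the earlier step is a weak guide.

For compound 4 a step of a 1.1-fold higher number from compound 2 to compound 4 (0.04 log units; within the scatter) from compound 2 is expected in this assay, which is smaller than the step from compound 3 to compound 1, because compound 2 already sits at 0.183 h and the change is on the ring carrying no ring nitrogen. Compound 4 is therefore estimated at 0.2 h in this assay, with a range from 0.1 h to 0.4 h.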

Compound 4, half-life: 0.217 h
Compound 4: the middle estimate sits 1.1-fold (0.04 log units) below what was measured; the range from low to high includes it.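

In this assay, hydrogen in place of methyl on an aromatic carbon of a six-membered aromatic ring of carbon only, meta to a large group, gives a 1.2-fold higher number from compound 2 to compound 4 (0.07 log units; within the scatter), so this change does not separate compound 2 from compound 4 on the core they share. The same kind of change, made at a different place and on a different core, gave a 7.1-fold higher number from compound 3 to compound 1 (0.85 log units; beyond the scatter), so the large step seen in that pair did not appear here, and the label "hydrogen in place of methyl" alone does not predict the size of the step across this series. With one pair at each place, the data cannot show whether the difference between the two steps follows from the place of the methyl, from the core or from the rest of the molecule, and nothing available here explains it.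

The compounds shown leave open how a methyl on the same six-membered ring would read on the core of compound 1, and how the methyl would read on the core of compound 2 with a longer chain in place of the one carried there. They also leave open how a chlorine, a methoxy group or a carboxylic acid at that aromatic carbon would read in this assay.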